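This account rests on a few compounds, and the source may have more. Where it says the series, first, only, none or still open, it means among the compounds named here.

Of the compounds shown here, three built on one shared core have been measured in a functional assay on MCF7 cells (Homo sapiens) for antiproliferative activity, read by MTT assay, with a stated time of 72 h; a higher number here means a weaker inhibitor, a lower number a stronger inhibitor. Compound 1 (`CCN1CCN(c2cc(C)c3cc(NC(=O)c4ccc(C)cc4)ccc3n2)CC1`), with 4-methylphenyl on the amide carbonyl carbon, gives 6740 nM. Compound 2 (`CCN1CCN(c2cc(C)c3cc(NC(=O)c4ccccc4)ccc3n2)CC1`), with phenyl there, gives 14200 nM. Compound 3 (`CCN1CCN(c2cc(C)c3cc(NC(=O)c4ccc5ccccc5n4)ccc3n2)CC1`), with quinolin-2-yl there, gives 7060 nM. Compound 3 stands within the usual scatter of both others, as the steps show: a 1.0-fold higher number from compound 1 to compound 3 (0.02 log units; within the scatter) and a 2.0-fold lower number from compound 2 to compound 3 (0.30 log units; within the scatter). Only the remaining step, a 2.1-fold higher number from compound 1 to compound 2 (0.32 log units; beyond the scatter), passes the scatter, and it is modest.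

Compound 4 (`CCN1CCN(c2cc(C)c3cc(NC(=O)c4cccc(F)c4)ccc3n2)CC1`) has not yet been measured. It has 3-fluorophenyl in place of quinolin-2-yl on a carbonyl carbon. Among the compounds with values here, no compound with fluorine has a measured value, so no step shows this change directly. The nearest guides are the exchanges at this same carbonyl carbon, and these stayed small, with a 2.0-fold lower number from compound 2 to compound 3 (0.30 log units; within the scatter) and a 1.0-fold higher number from compound 1 to compound 3 (0.02 log units; within the scatter) as the examples. A step beyond the scatter is therefore not expected in this assay, in either direction. The estimated step is a 1.3-fold higher number from compound 3 to compound 4 (0.11 log units; within the scatter). For compound 4 the expected value is 9000 nM, with an estimated range from 4500 nM to 18000 nM.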

Compound 4, half-maximal inhibitory concentration: 8920 nM
Beside the measured number, compound 4's estimate is 1.0-fold (0.00 log units) above it, and the stated range covers the measured number.
By their numbers in this assay, from the lowest: compounds 1, 3, 4 and 2 (each within the scatter of the next, the first and the last beyond it).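

In this assay, 3-fluorophenyl on the carbonyl carbon stays within the scatter of quinolin-2-yl (a 1.3-fold higher number from compound 3 to compound 4 (0.10 log units; within the scatter)) and of 4-methylphenyl (a 1.3-fold higher number from compound 1 to compound 4 (0.12 log units; within the scatter)), so this position has now taken a group carrying fluorine as well as a two-ring group and a methyl-bearing ring without a step beyond the scatter among these three. Fluoro in place of hydrogen on an aromatic carbon also stays within the scatter (a 1.6-fold lower number from compound 2 to compound 4 (0.20 log units; within the scatter)), so compound 4 sits within the scatter of all three earlier compounds, and the only pair still beyond it is compound 1 and compound 2. No measurement here explains why these exchanges give such small steps.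

As far as these compounds go, whether 4-fluorophenyl, 3-chlorophenyl, or a phenyl ring carrying an amine or a carboxylic acid would stay in this same narrow band remains open. So does whether a chain such as a longer alkyl group, or a ring without aromatic character, on this carbonyl carbon would produce a step beyond the scatter.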